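Capping the Terminal Alkyne: From Compound 2 to Compound 3

The compounds below may be only part of what the source reports. "The series", "measured", "known", "first", "only" and "open" are said of these compounds alone.

Measured compounds in an assay on cells (Hepatocyte) for inhibition of glucokinase regulatory protein (Mus musculus), with stated times of 20 min and 40 min; on this read-out lower numbers stand for an effect already at smaller amounts and higher numbers for an effect only at larger amounts of compound:
Compound 1, `CC#C[C@H]1CN(S(=O)(=O)c2ccc(N)nc2)CCN1c1ncc(C(C)(O)C(F)(F)F)s1`: > 12500 nM
Compound 2, `C#CCC(O)(c1ccc(N2CCN(S(=O)(=O)c3ccc(N)nc3)C[C@@H]2C#CC)cc1)C(F)(F)F`: 130 nM

For the measured compounds named here, only two compounds have been measured in this assay. Compound 1 returns a limit rather than a number, namely (the limit of > 12500 nM in this assay, at which 1 of the 2 values shown sits). Going by the values given here, compound 2 gives 130 nM, which is the only real number among the measurements so far. The value of compound 1 is only a limit. Among the compounds with values here, no step between measured compounds can be worked out, and there is no measured pattern to lean on.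

Compound 3, `CC#CCC(O)(c1ccc(N2CCN(S(=O)(=O)c3ccc(N)nc3)C[C@@H]2C#CC)cc1)C(F)(F)F`, is the compound still to be measured. It differs from compound 2 by a single small change: methyl in place of hydrogen on a triple-bonded carbon. Within the data shown here, because no step between measured compounds is available, the expectation for this change has to be modest and cautious. Compound 3 is expected to give about 130 nM in this assay, with a range from 50 nM to 400 nM. The step this implies, no change at the digits printed from compound 2 to compound 3 (within the scatter), is expected to stay within the usual scatter of repeated measurements, in no clear direction.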

Compound 3, half-maximal effective concentration: 137 nM
The estimate for compound 3 lay 1.1-fold (0.02 log units) below the measured number; low and high end bracket the measured number.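

In this assay, for the compounds shown here, the change of methyl in place of hydrogen on a triple-bonded carbon, which turns the propargyl group into but-2-yn-1-yl, gives a 1.1-fold higher number from compound 2 to compound 3 (0.02 log units; within the scatter) and is the first step that can be read at this position. The two compounds cannot be told apart in this measurement, so for this one pair, the added methyl leaves the read-out where it was. Nothing in the data shown explains this result.

This single small step leaves open how far the same triple-bonded carbon tolerates change: a longer chain such as propyl, a ring such as cyclopropyl, or a group carrying a hydroxyl or an amine could behave quite differently from methyl. The steps to compound 1 cannot be read, as it differs from the other two compounds in more than one place and its value is only a limit, so the compounds shown also leave open which of those differences matters in this assay for the gap between it and the others.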